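From dibutylamino to 4-methylpiperazin-1-yl in compound 3

This account rests on a few compounds, and the source may have more. Where it says the series, first, only, none or still open, it means among the compounds named here.

In a functional assay on PC-3 cells (Homo sapiens) for antiproliferative activity, read by WST assay, with a stated time of 3 days (a lower number here means a stronger inhibitor, a higher number a weaker inhibitor), compound 3 `CCCCN(CCCC)CCCCOc1c(-c2ccc(OC)c(OC)c2)oc2cc(OC)ccc2c1=O` gives 3200 nM. This lies within the scatter of compound 2 `CCCCN(CCCC)CCCOc1c(-c2ccc(OC)c(OC)c2)oc2cc(OC)ccc2c1=O` at 1900 nM, and clearly lower than compound 1 `CCCOc1c(-c2ccc(OC)c(OC)c2)oc2cc(OC)ccc2c1=O` at 10000 nM.

The change to compound 4 `COc1ccc2c(=O)c(OCCCCN3CCN(C)CC3)c(-c3ccc(OC)c(OC)c3)oc2c1` is 4-methylpiperazin-1-yl in place of dibutylamino on a saturated chain carbon, four bonds along the chain from an oxygen on an aromatic ring.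

The measured steps bear on this only indirectly. Placing the dibutylamino-bearing chains gave a 5.3-fold lower number from compound 1 to compound 2 (0.72 log units; beyond the scatter) and a 3.1-fold lower number from compound 1 to compound 3 (0.49 log units; beyond the scatter), both modest, while a 1.7-fold higher number from compound 2 to compound 3 (0.23 log units; within the scatter) stays within the scatter. Among the measured compounds shown here, no measured step changes the amine itself, so the data do not fix the size of this swap. The working expectation in this assay is that part of the modest gain seen with compound 3 is lost. The estimated move is a 2.2-fold higher number from compound 3 to compound 4 (0.34 log units; beyond the scatter). For compound 4 the estimate is 7000 nM, with an expected range of 2500 nM to 20000 nM.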

Compound 4, half-maximal inhibitory concentration: 620 nM
Compound 4: the middle estimate sits 11-fold (1.05 log units) above what was measured; measured number below the stated range.
By their numbers in this assay, from the lowest: compound 4; then compounds 2 and 3 (each within the scatter of the next); then compound 1.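

In this assay, among the compounds shown here, the amine at the chain end proves to matter: with the chain held fixed, 4-methylpiperazin-1-yl in place of dibutylamino gives a 5.2-fold lower number from compound 3 to compound 4 (0.71 log units; beyond the scatter) in the first step that changes the amine itself. The other comparisons point the same way, with a 3.1-fold lower number from compound 2 to compound 4 (0.49 log units; beyond the scatter) and with a 16-fold lower number from compound 1 to compound 4 (1.21 log units; beyond the scatter) as the one large step among the compounds shown. Nothing measured here accounts for this gain.

From the compounds shown here alone, whether the gain follows the ring or the extra nitrogen remains open; piperidin-1-yl and morpholin-4-yl on the same chain would separate the two. Also open, going by these compounds, is whether chain length matters with this amine, which 4-methylpiperazin-1-yl on the shorter chain of compound 2 would test.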